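Fluoro Added to a Partial Agonist Core

This account rests on a few compounds, and the source may have more. Where it says the series, first, only, none or still open, it means among the compounds named here.

Measured compounds:
- compound 1 `O=S(=O)(c1cccc(F)c1)c1cn(C2CCNC2)c2ccc(Cl)cc12`: "not determined" (no result reported) in a functional assay on HeLa cells for agonist activity at 5-hydroxytryptamine receptor 6 (Homo sapiens), read by cAMP accumulation and immunoassay, with a stated time of 10 min; a lower number here means a smaller maximal response, a higher number a larger maximal response
- compound 2 `O=S(=O)(c1cccc(F)c1)c1cn(C2CCNC2)c2ccccc12`: 38%

Compound 2 stands alone with a number in this assay; compound 1 offers no value to compare against. Compound 3 `O=S(=O)(c1cccc(F)c1)c1cn(C2CCNC2)c2ccc(F)cc12` differs from compound 2 by one change: fluoro in place of hydrogen on an aromatic carbon. With no measured step of this kind shown, nothing indicates a change beyond the usual scatter in either direction. Compound 3 is therefore expected to give about 40%, within a range of 22% to 58%. The expected step of a number 2 percentage points higher from compound 2 to compound 3 (within the scatter) is estimated to be small.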

Compound 3, largest response reached (Emax), in percent of the reference or control that the assay uses: 50%
Estimate against measurement, compound 3: 10 percentage points below; low and high end bracket the measured number.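

In this assay, fluoro in place of hydrogen on this aromatic carbon, para to a fused ring, gives a number 12 percentage points higher from compound 2 to compound 3 (beyond the scatter). This shows that the maximal response at this receptor is sensitive to a change of a single atom at this position. Nothing shown gives a reason for the rise.

Going by these compounds alone, compound 1 carries chloro at the same carbon but has no number, so no step involving it can be read. From the compounds shown here alone, how a methoxy group or an amine would behave at this carbon remains open.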